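The source may report more compounds than this note shows. Statements on the series, on what has been measured and on what is new or still open speak of the compounds shown alone.

Compound 1 `Cc1ccc(-c2cnn3c(NCc4ccccn4)cc(C)nc23)cc1` — < 5000 nM
Compound 2 `Cc1cc(OCc2ccccn2)n2nc(C)c(-c3ccccc3)c2n1` — 25600 nM

Both compounds were run in a physicochemical assay for solubility, read by HPLC, using the shake flask method, measured as kinetic solubility, with a stated time of 2 h, at pH 7.4; on this read-out lower numbers stand for lower solubility and higher numbers for higher solubility. For compound 1 the value < 5000 nM is a limit of the assay and not a number, so its solubility is known only as sitting at that boundary (the limit of < 5000 nM in this assay, at which 1 of the 2 values shown sits). Compound 2, in the same assay, gives a measured figure, 25600 nM. For the measured compounds named here, these two compounds differ in more than one place, so no single step connects them; their values show only one compound at the limit and one with a number.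

Compound 3 `Cc1cc(NCc2ccccn2)n2ncc(-c3ccncc3)c2n1` has not yet been measured. It differs from compound 1 in one place: pyridin-4-yl in place of 4-methylphenyl on an aromatic carbon. Going by the values given here, no measured pair here shows what such a change does to solubility, so the size of the step rests on estimate alone. The expected step is an at least 3.0-fold higher number from compound 1 to compound 3 (0.47 log units; beyond the scatter), toward higher solubility but not large. Compound 3 is estimated at 15000 nM, within a range from 3000 nM to 60000 nM.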

Compound 3, solubility: 161000 nM
For compound 3 the middle estimate is 11-fold (1.03 log units) below the measured one; the whole stated range lies below it.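

In this assay, for the compounds shown here, putting pyridin-4-yl in place of 4-methylphenyl on an aromatic carbon of the five-membered aromatic ring gives the first readable step at this position: an at least 32-fold higher number from compound 1 to compound 3 (1.50 log units; beyond the scatter). The change in atoms is small, since a six-membered aromatic ring of carbon only gives way to a six-membered aromatic ring with 1 hetero atom, yet the step is large. The value of compound 1, < 5000 nM, is a limit and not a number, so the step gives only a lower bound on the change: the limit of < 5000 nM in this assay, at which 1 of the 3 values shown sits.

The compounds shown leave open whether the place of the nitrogen in the ring matters, as pyridin-3-yl would test, or whether an amine or a carboxylic acid on this carbon would give a similar step. On these data alone, this change is seen in a single pair, so whether it carries over to a compound such as compound 2 is unknown.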